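Shortening a Chain on a Core That Shows No Activity

A few compounds are considered here, and "the series" means these few. Any claim that something is new, unique, unknown or untested is made for them only; others in the source may bear on it.

Of the compounds shown here, three of one small series have been tested in a functional assay for inhibition, with Homo sapiens as the target; a higher number here means a weaker inhibitor, a lower number a stronger inhibitor. Compound 1 `CC(C)c1ncn2c(S)nncc12` gives in this assay only a limit of the assay, > 48000 nM. Compound 2 `CNc1nncc2c(C)ncn12` likewise reaches in this assay only a limit, > 48000 nM. Compound 3 `CCc1ncn2c(S)nncc12` stands at a limit too, giving in this assay > 48000 nM. So compound 3 has no number of its own; all that is known is where it does not reach, a position it shares with the other two, as the limit of > 48000 nM in this assay, at which 3 of the 3 values shown sit, records.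

Compound 4 `Cc1ncn2c(S)nncc12` differs from compound 3 by hydrogen in place of methyl on a saturated chain carbon bound to an aromatic carbon. Within the data shown here, the one measured step that resembles it is a step that the two limits leave unreadable from compound 1 to compound 3, a like removal of methyl one bond further out, and since both ends of that step sit at a limit its size cannot be read. Among the measured compounds shown here, no measured step therefore gives a direction for the change in this assay; with every neighbour at the limit, the expected step is a step that the limit leaves unreadable from compound 3 to compound 4. Compound 4 is accordingly expected to give in this assay about 60000 nM, somewhere between 20000 nM and 200000 nM, most likely reported again only as a limit.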

Compound 4, half-maximal inhibitory concentration: > 48000 nM
Compound 4 gave a limit, no number; the forecaster's own chance of this, stated with the estimate: 85%; the middle value does not contradict the limit.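

Among these compounds, no step from compound 1, compound 2 or compound 3 to compound 4 can be read, since compound 4 also gives only a limit and no number: the limit of > 48000 nM in this assay, at which 4 of the 4 values shown sit. The compounds shown leave open whether any change to the shared core gives a measurable value in this assay at all.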